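This account rests on a few compounds, and the source may have more. Where it says the series, first, only, none or still open, it means among the compounds named here.

In a functional assay on MCF7 cells (Homo sapiens) for cytotoxicity, read by MTT assay, with a stated time of 72 h (a lower number here means a stronger inhibitor, a higher number a weaker inhibitor), compound 1 `CCCCc1ccc(NC(=O)CSC(=S)N[C@H]2CCOC2=O)cc1` gives 40200 nM. Compound 2 `CCSC(=S)N[C@H]1CCOC1=O` gives no number in this assay, only a limit, > 128000 nM. Where compound 2 stands is therefore fixed only by the limit of > 128000 nM in this assay, at which 1 of the 2 values shown sits; nothing finer is known about it. Compound 3 `CCCCCCSC(=S)N[C@H]1CCOC1=O` differs from compound 2 by butyl in place of hydrogen on a saturated chain carbon, two bonds along the chain from a sulfur. Going by the values given here, no measured step connects these two compounds, and the only other measured value, that of compound 1, belongs to a structure that differs in several places at once. With compound 2 sitting at a limit, a modest step toward stronger inhibition in this assay is expected from the added butyl, but it may not pass beyond the usual scatter, and a further limit result is nearly as likely as a number. Compound 3 is expected to give about 90000 nM in this assay, within 30000 nM to 250000 nM. This estimate corresponds to an expected step of an at least 1.4-fold lower number from compound 2 to compound 3 (0.15 log units; that floor lies within the scatter).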

Compound 3, half-maximal inhibitory concentration: > 128000 nM
Compound 3 gave a limit, no number; the forecaster's own chance of this, stated with the estimate: 50%; middle value at least 1.4-fold (0.15 log units) from the limit.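

In this assay compound 2 and compound 3 both give only a limit, not a number, and no step can be read between them. On these data alone, whether butyl in place of hydrogen at this place changes the value at all stays open.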